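The compounds below may be only part of what the source reports. "The series", "measured", "known", "first", "only" and "open" are said of these compounds alone.

So far, two compounds that differ in their side groups have been measured in a physicochemical assay for lipophilicity, read by HPLC, measured as chromatographic lipophilicity, at pH 7.4; on this read-out lower numbers stand for lower lipophilicity and higher numbers for higher lipophilicity. Compound 1 (`Cc1nnc(N2CCC(C(=O)N3N=CC[C@H]3c3ccccc3)CC2)o1`) gives 3.2, and compound 2 (`O=C(C1CCOC1)N1N=CCC1c1ccccc1`) gives 3. These two numbers lie within the usual scatter of repeated measurements, so this assay cannot tell compound 2 apart from compound 1.

Compound 3 (`O=C(c1ccccc1)N1N=CCC1c1ccccc1`) has not yet been measured. It keeps the core of compound 2 and alters one group, with phenyl in place of oxolan-3-yl on a carbonyl carbon. For the measured compounds named here, no measured pair shows this swap on its own, so the data give no direct guide to the size of the step. The expectation rests on the structural change alone: an all-carbon aromatic ring enters, and a non-aromatic ring holding an oxygen leaves. A move toward higher numbers, clearly beyond the scatter, is therefore expected. The estimated change is a number 1.20 log units higher from compound 2 to compound 3 (beyond the scatter). The estimated value for compound 3 is 4.2, with an expected range from 3.7 to 4.8.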

Compound 3, distribution coefficient: 4.6
For compound 3 the middle estimate is 0.40 log units below the measured one, within the range that was stated.
By their numbers in this assay, from the lowest: compounds 2 and 1 (each within the scatter of the next); then compound 3.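

In this assay the group on this carbonyl carbon, whose other neighbours are an amide-type nitrogen in a ring, proves able to move the read-out by a wide margin: phenyl in place of oxolan-3-yl gives a number 1.60 log units higher from compound 2 to compound 3 (beyond the scatter) and this counts as a large step. The swap changes several things at once, since a five-membered non-aromatic ring with a hetero atom and a hydrogen-bond acceptor leaves and a six-membered aromatic ring of carbon only enters, so this single pair cannot assign the step to any one of those differences. Nothing measured here explains the size of this step.

The compounds shown leave open how much of the step belongs to the aromatic ring and how much to the loss of the ring oxygen: cyclohexyl, a non-aromatic ring of carbon only, or pyridyl, an aromatic ring holding a nitrogen, on the same carbonyl carbon would help to separate the two. As far as these compounds go, it also remains open whether the same swap would give a step of similar size on a different core.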